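The source may hold more compounds than are shown below. What is called first, only, known or untested is meant among the compounds shown, and "the series" means these compounds.

Measured compounds:
compound 1, `CCOC(=O)C(=CNc1ccc2c(c1)C(Nc1ccc(Cl)cc1)=NS2(=O)=O)C(=O)OCC`: 2.39
compound 2, `O=C(Nc1ccc(Br)cc1)Nc1ccc(OC2=NS(=O)(=O)c3ccccc32)cc1`: 3.64
compound 3, `O=C(O)CCC(=O)Nc1ccc2c(c1)C(Nc1cccc(Br)c1)=NS2(=O)=O`: 1.26

In a physicochemical assay for lipophilicity (on this read-out lower numbers stand for lower lipophilicity and higher numbers for higher lipophilicity), compound 1 stands second highest of the three; compound 3 lies lower and compound 2 lies higher, both gaps beyond the scatter. Compound 4, `CCOC(=O)C(=CNc1ccc2c(c1)C(Nc1cccc(Br)c1)=NS2(=O)=O)C(=O)OCC`, has not yet been measured in this assay. It differs from compound 1 in one place: 3-bromophenyl in place of 4-chlorophenyl on an amine nitrogen. For the measured compounds named here, no step between measured compounds shows what such a swap does in this assay. Since the change exchanges one halogen-bearing phenyl for another of equal size, the step from compound 1 to compound 4 is expected to be small, if anything a slight rise, and likely within the scatter, a number 0.16 log units higher from compound 1 to compound 4 (within the scatter). Compound 4 is therefore estimated at 2.55, in the range 2.1 to 3.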

Compound 4, partition coefficient: 2.48
Beside the measured number, compound 4's estimate is 0.07 log units above it, within the range that was stated.
By their numbers in this assay, from the lowest: compound 3; then compounds 1 and 4 (each within the scatter of the next); then compound 2.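

For the compounds shown here, this is the first step read at this position: in this assay, 3-bromophenyl in place of 4-chlorophenyl on an amine nitrogen gives a number 0.09 log units higher from compound 1 to compound 4 (within the scatter) and so leaves the two compounds indistinguishable on this read-out. Nothing available explains this result. The swap alters the halogen and its position together, so the contribution of each cannot be read separately. From the compounds shown here alone, what a carboxylic acid, an amine or a longer chain on the phenyl ring would do at this nitrogen remains open.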